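The source may hold more compounds than are shown below. What is called first, only, known or untested is meant among the compounds shown, and "the series" means these compounds.

The three measured compounds share a core in which two acyl groups flank a selenium- or sulfur-bearing centre. Compound 1 `C[Se]/C(=N\C(=O)c1cc2ccccc2s1)NC(=O)c1cc2ccccc2s1` gives 65600 nM in a functional assay on PC-3 cells (Homo sapiens) for cytotoxicity, read by MTT assay, with a stated time of 72 h; on this read-out lower numbers stand for stronger inhibition of growth and higher numbers for weaker inhibition of growth. Compound 3 `C[Se]/C(=N\C(=O)c1cnc2ccccc2c1)NC(=O)c1cnc2ccccc2c1` gives 43600 nM in this assay. Compound 2 `CS/C(=N\C(=O)c1cc(-c2ccccc2)nc2ccccc12)NC(=O)c1cc(-c2ccccc2)nc2ccccc12` reaches only a limit in this assay, > 100000 nM, rather than a number (the limit of > 100000 nM in this assay, at which 1 of the 3 values shown sits). Compound 3 thus stands at the lowest of the two numbers, but the number of compound 1 lies within the usual scatter of it, so no order between compound 1 and compound 3 can be read from these values.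

Compound 4 `O=C(/N=C(/NC(=O)c1cnc2ccccc2c1)[Se]Cc1ccccc1)c1cnc2ccccc2c1` has not yet been measured. It differs from compound 3 by phenyl in place of hydrogen on a saturated chain carbon bound to a selenium atom. Within the data shown here, no pair of measured compounds differing in one place is available, so there is nothing to anchor a direction; the step of a 1.2-fold lower number from compound 3 to compound 4 (0.10 log units; within the scatter) is expected to stay within the scatter. Compound 4 is therefore expected to give 35000 nM in this assay, estimated between 12000 nM and 100000 nM.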

Compound 4, concentration for total growth inhibition: > 100000 nM
Compound 4: no number, only a limit; the forecaster's own chance of this, stated with the estimate: 20%; middle value at least 2.8-fold (0.45 log units) away from the limit.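

Compound 4 reaches only a limit in this assay, not a number: the limit of > 100000 nM in this assay, at which 2 of the 4 values shown sit.

Among these compounds, this gives the first step in the set that can be read, an at least 2.2-fold higher number from compound 3 to compound 4 (0.36 log units; beyond the scatter), and it shows that the place is not indifferent to change. Phenyl in place of hydrogen on a saturated chain carbon bound to a selenium atom, the change from methyl to benzyl, moves the read-out towards weaker inhibition of growth, with the full size of the step left undefined by the limit.

The compounds shown leave open whether an ethyl group or a longer chain at this place would stay close to compound 3 or fall away like compound 4. They also leave open how an amine or a carboxylic acid on that chain would behave.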